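The compounds below may be only part of what the source reports. "The series", "measured", "known", "first", "only" and "open" are said of these compounds alone.

Measured compounds:
compound 1, `CC1=NC=CC(c2c(C)sc3ccccc23)N1`, 30 mg/kg
compound 2, `CC1=CN=CNC1c1c(C)sc2ccccc12`, 30 mg/kg

Both were run in a functional assay on the whole organism with Mus musculus as the target, with a stated time of 15 min; on this read-out lower numbers stand for an effect already at smaller amounts and higher numbers for an effect only at larger amounts of compound. In this assay compound 1 gives 30 mg/kg and compound 2 gives 30 mg/kg, so compound 2 stands level with compound 1 at the digits shown; the two values lie within the usual scatter of each other and no order between them can be drawn.

The next compound, compound 3, is `Cc1sc2ccccc2c1C1C=CN=CN1`. Relative to compound 2 the change is small: hydrogen in place of methyl on a double-bonded ring carbon. The methyl is removed from the six-membered non-aromatic ring with two nitrogens and nothing else in the molecule moves.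

Among the measured compounds shown here, no measured pair in this set shows the effect of such a change, so there is no step to lean on. The two values available, both at the same level, give no hint that a single methyl on this ring carries the read-out. The working expectation for compound 3 is therefore a step of about no change at the digits printed from compound 2 to compound 3 (within the scatter), that is none beyond the scatter, with the value expected at 30 mg/kg in a range from 10 mg/kg to 100 mg/kg.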

Compound 3, minimum effective dose: 3 mg/kg
For compound 3 the middle estimate is 10-fold (1.00 log units) above the measured one; measured number outside the range, below it.
By their numbers in this assay, from the lowest: compound 3; then compounds 1 and 2 (each within the scatter of the next).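

Hydrogen in place of methyl on a double-bonded ring carbon gives a 10-fold lower number from compound 2 to compound 3 (1.00 log units; beyond the scatter) in this assay, so this ring position responds to the loss of a single methyl, which the level values of compound 1 and compound 2 could not show. Hydrogen in place of methyl on a carbon with a double bond to nitrogen gives a 10-fold lower number from compound 1 to compound 3 (1.00 log units; beyond the scatter) as well, so compound 3 stands apart from both methyl-bearing compounds, and either methyl placement goes with the higher number in this read-out. No measurement in hand accounts for the difference between the methyl and hydrogen compounds.

As far as these compounds go, whether the lower number at these ring carbons is specific to hydrogen remains open: an ethyl, a hydroxyl or an amine at the double-bonded ring carbon would test how far this position tolerates anything beyond hydrogen. Also open, from the compounds shown here alone, is how much the methyl on the rest of the shared core contributes, since it stays the same in all three compounds and a version carrying hydrogen or ethyl there would be needed to judge it.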